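The compounds below may be only part of what the source reports. "The series", "measured", "known", "first", "only" and "open" are said of these compounds alone.

Compound 1 `Cc1ccc(-c2cnc(NC(=O)c3ccc(F)cc3)n2C)cc1` gives 60000 nM in a toxicity assay on THP-1 cells (Homo sapiens) for inhibition; on this read-out lower numbers stand for higher toxicity in this test and higher numbers for lower toxicity in this test.
Compound 2 `COc1ccc(-c2cnc(NC(=O)c3cccc(O)c3)n2C)cc1` gives > 100000 nM in this assay, a limit of the assay rather than a number.
Compound 3 `O=C(Nc1ncc(-c2ccccc2)o1)c1ccc(F)cc1` gives 17000 nM in this assay.

Among these values compound 2 stands at the limit of > 100000 nM in this assay, at which 1 of the 3 values shown sits; only that limit is known for it, not a number. Compound 4 `COc1ccc(-c2cnc(NC(=O)c3ccccn3)n2C)cc1` has not yet been measured. It differs from compound 2 in one place: pyridin-2-yl in place of 3-hydroxyphenyl on a carbonyl carbon. Among the compounds with values here, no two measured compounds differ in exactly one place, so no measured step shows what such a swap does in this assay. The expected step of an at least 1.1-fold lower number from compound 2 to compound 4 (0.04 log units; that floor lies within the scatter) is therefore no more than the scatter, in either direction. Compound 4 is estimated at 90000 nM, between 35000 nM and 200000 nM, with a real chance that only a limit is reported again.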

Compound 4, half-maximal cytotoxic concentration: > 100000 nM
Compound 4: no number, only a limit; the forecaster's own chance of this, stated with the estimate: 45%; middle value at least 1.1-fold (0.04 log units) away from the limit.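

Compound 2 and compound 4 both end at a limit of the assay rather than a number, so no step between them can be read: the limit of > 100000 nM in this assay, at which 2 of the 4 values shown sit.

The compounds shown leave open how far pyridin-2-yl in place of 3-hydroxyphenyl on a carbonyl carbon moves the read-out in this assay.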